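Removing the Halogen from a Tetrazole Thioether Series

The source may report more compounds than this note shows. Statements on the series, on what has been measured and on what is new or still open speak of the compounds shown alone.

Compound 1 `Cc1nnc(SCC(=O)N/N=c2/scc(-c3ccccc3)n2-c2ccccc2)s1`: 197 ug/mL
Compound 2 `Cn1nnnc1SCC(=O)N/N=c1/scc(-c2ccc(Br)cc2)n1-c1ccccc1`: 19.3 ug/mL
Compound 3 `Cn1nnnc1SCC(=O)N/N=c1/scc(-c2ccc(Cl)cc2)n1-c1ccccc1`: 40 ug/mL

In an ADME assay on NIH3T3 cells (Mus musculus) for cytotoxicity, read by MTT assay, with a stated time of 24 h (a lower number here means a stronger inhibitor, a higher number a weaker inhibitor), compound 3 gives 40 ug/mL, the second highest of the three numbers shown. Compound 2 gives 19.3 ug/mL, and compound 1 gives 197 ug/mL. Compound 4 `Cn1nnnc1SCC(=O)N/N=c1/scc(-c2ccccc2)n1-c1ccccc1` has not yet been measured in this assay. The change from compound 3 to compound 4 is hydrogen in place of chloro on an aromatic carbon, on an aromatic carbon of a six-membered aromatic ring of carbon only. Among the compounds with values here, one measured step bears on it: a 2.1-fold higher number from compound 2 to compound 3 (0.32 log units; beyond the scatter), a change at the same ring. Compound 1, which carries an unsubstituted phenyl at that place but a different heterocycle on the thioether side, gives 197 ug/mL. The two halogen compounds and compound 1 together point toward a higher number once the halogen is gone. Compound 4 is therefore expected to give 90 ug/mL in this assay, with a range of 35 ug/mL to 250 ug/mL. The expected step of a 2.3-fold higher number from compound 3 to compound 4 (0.35 log units; beyond the scatter) is a modest rise beyond the scatter.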

Compound 4, half-maximal inhibitory concentration: 173 ug/mL
Compound 4: middle estimate off by 1.9-fold (0.28 log units), on the low side; the measured number falls inside the stated range.
By their numbers in this assay, from the lowest: compound 2; then compound 3; then compounds 4 and 1 (each within the scatter of the next).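

In this assay, taking the halogen off this ring altogether gives a 4.3-fold higher number from compound 3 to compound 4 (0.64 log units; beyond the scatter) for the step from 4-chlorophenyl to phenyl, and replacing bromo with hydrogen gives a 9.0-fold higher number from compound 2 to compound 4 (0.95 log units; beyond the scatter). Among these three compounds, the number therefore rises in the order bromo, chloro, hydrogen, with no compound going against that order. With the unsubstituted phenyl in place, 1-methyl-1H-tetrazol-5-yl in place of 5-methyl-1,3,4-thiadiazol-2-yl on the sulfur gives a 1.1-fold lower number from compound 1 to compound 4 (0.06 log units; within the scatter), so the two heterocycles cannot be told apart in this comparison.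

Going by these compounds, whether a methoxy group or an amine at this place would fit the same order remains open. Nothing available explains why the number rises when the halogen is removed.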